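This account rests on a few compounds, and the source may have more. Where it says the series, first, only, none or still open, it means among the compounds named here.

Within the data shown here, in an assay on isolated protein for inhibition of Tryptophan 2,3-dioxygenase (Homo sapiens), read by spectrophotometry, with a stated time of 1 h (a lower number here means a stronger inhibitor, a higher number a weaker inhibitor), compound 2 `O=[N+]([O-])c1ccc(N/C(=N\O)c2ccc(F)cc2)c2nonc12` gives 21000 nM, the lowest of the two numbers recorded so far; its only neighbour, compound 1 `O=[N+]([O-])c1ccc(N/C(=N\O)c2ccccc2F)c2nonc12`, gives 110000 nM. Among the measured compounds shown here, the single measured step, a 5.2-fold lower number from compound 1 to compound 2 (0.72 log units; beyond the scatter), concerns where the fluorine sits on the ring, not which halogen it is. Compound 3 `O=[N+]([O-])c1ccc(N/C(=N\O)c2ccc(Br)cc2)c2nonc12` differs from compound 2 by bromo in place of fluoro on an aromatic carbon. For the measured compounds named here, no measured step bears on exchanging one halogen for another at the same place, so the step of a 1.4-fold lower number from compound 2 to compound 3 (0.15 log units; within the scatter) is expected to stay within the usual scatter. Compound 3 is therefore estimated at 15000 nM, with a range of 4000 nM to 60000 nM.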

Compound 3, half-maximal inhibitory concentration: 50000 nM
Beside the measured number, compound 3's estimate is 3.3-fold (0.52 log units) below it, within the range that was stated.
By their numbers in this assay, from the lowest: compound 2; then compound 3; then compound 1.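

In this assay the identity of the halogen at this ring carbon counts, not only where it sits: bromo in place of fluoro gives a real change (a 2.4-fold higher number from compound 2 to compound 3 (0.38 log units; beyond the scatter)). The 4-bromophenyl group still reads better than 2-fluorophenyl (a 2.2-fold lower number from compound 1 to compound 3 (0.34 log units; beyond the scatter)), so this change does not undo the whole gain seen with the 4-substituted ring. No evidence is available on what lies behind these steps. The compounds shown leave open how chloro at the same place would read, and whether a non-halogen group, such as an amine or a methoxy group, would give a lower number.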